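The source may hold more compounds than are shown below. What is called first, only, known or untested is meant among the compounds shown, and "the series" means these compounds.

In a functional assay on PC-3 cells (Homo sapiens) for antiproliferative activity (a lower number here means a stronger inhibitor of growth, a higher number a weaker inhibitor of growth), compound 1 `Cc1cc(C)c2c(O)cc(-c3cccc(Cl)c3)nc2n1` gives 27.5 nM. Compound 2 `Cc1cnc2[nH]c(-c3cccc(Cl)c3)cc(=O)c2c1` reads > 100000 nM, which is a limit of the assay and not a number. Compound 2 therefore stands at the limit of > 100000 nM in this assay, at which 1 of the 2 values shown sits. Among the compounds with values here, no two measured compounds differ in only one place, so no measured step is available to guide the next reading. Compound 3 `Cc1cnc2[nH]c(-c3cccc(F)c3)cc(=O)c2c1` departs from compound 2 by fluoro in place of chloro on an aromatic carbon, with fluoro in place of chloro on an aromatic carbon, meta to a large group. In this assay, only a small move toward stronger growth inhibition is expected, and a second reading at the limit is considered the likeliest result. The expected change is an at least 1.2-fold lower number from compound 2 to compound 3 (0.09 log units; that floor lies within the scatter). Compound 3 is estimated at 80000 nM, with an expected range of 20000 nM to 100000 nM.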

Compound 3, concentration for 50% growth inhibition: 34.7 nM
Estimate against measurement, compound 3: 2300-fold (3.36 log units) above, outside the stated range (below it).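

In this assay compound 2 reads > 100000 nM, which is a limit of the assay and not a number. Fluoro in place of chloro on this aromatic carbon, meta to a large group, gives an at least 2800-fold lower number from compound 2 to compound 3 (3.45 log units; beyond the scatter), so in this series a change of a single halogen at this position can separate a compound at the limit from one with a measurable value. The size of this step is only a floor, because one end of it is a limit: the limit of > 100000 nM in this assay, at which 1 of the 3 values shown sits.

On these data alone, it remains open how other groups at this position would read, such as a methoxy group, an amine or a nitrile, and whether the response depends on the halogen itself or on this particular pair. As far as these compounds go, compound 1 differs from compound 3 in more than one place, so it also remains open whether fluoro in place of chloro would give a step of this size on the core of compound 1.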